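Compound 2 and an added methoxy: working notes

A few compounds are considered here, and "the series" means these few. Any claim that something is new, unique, unknown or untested is made for them only; others in the source may bear on it.

Among the measured compounds shown here, only two compounds have numbers so far in a functional assay on DU-145 cells (Homo sapiens) for cytotoxicity, read by trypan blue exclusion, with a stated time of 96 h (a lower number here means a stronger inhibitor, a higher number a weaker inhibitor), and no single-place step connects them. Compound 1 (`COc1ccc(CS(=O)(=O)/C=C/c2ccccc2OC)cc1N`) gives 7500 nM and compound 2 (`COc1ccc(/C=C/S(=O)(=O)Cc2ccc(OC)c(N)c2)cc1`) gives 2500 nM as the lower of the two numbers, with a gap beyond the usual scatter.

Compound 3 (`COc1ccc(/C=C/S(=O)(=O)Cc2ccc(OC)c(N)c2)c(OC)c1`) departs from compound 2 in one place: methoxy in place of hydrogen on an aromatic carbon with methoxy in place of hydrogen on an aromatic carbon, ortho to a large group and meta to a methoxy group.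

For the measured compounds named here, no measured step shows what such a replacement does, so the expectation is loose. Compound 1 and compound 2 each already carry a methoxy on the aromatic ring that changes here, and both stay in the same broad range of numbers. A further methoxy is expected to move the number in this assay downward by a moderate amount, probably beyond the scatter, though no change cannot be excluded. The expected move is a 3.6-fold lower number from compound 2 to compound 3 (0.55 log units; beyond the scatter) in this estimate. For compound 3 the estimated value is 700 nM with an expected range from 100 nM to 4000 nM at this stage.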

Compound 3, half-maximal inhibitory concentration: 500 nM
Compound 3: the middle estimate sits 1.4-fold (0.15 log units) above what was measured; the range from low to high includes it.
By their numbers in this assay, from the lowest: compound 3; then compound 2; then compound 1.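

In this assay, among the compounds shown here, this is the first measured case of methoxy in place of hydrogen on an aromatic carbon, ortho to a large group and meta to a methoxy group, and it gives a 5.0-fold lower number from compound 2 to compound 3 (0.70 log units; beyond the scatter) with no loss of activity at this place. For the compounds shown here, the step recorded from the other earlier compound, a 15-fold lower number from compound 1 to compound 3 (1.18 log units; beyond the scatter), is larger, and compound 3 now has the lowest number, with both of its steps beyond the scatter; the second methoxy on this ring therefore goes with stronger inhibition in the one direct comparison available, and nothing among the three compounds runs against that. Nothing available accounts for the size of either step.

Still open, going by these compounds, is whether a hydroxyl, a chlorine atom or a longer ethoxy chain at this same place would go with a number like that of compound 3 or whether the result is particular to methoxy. Also open, on these data alone, is whether the same replacement would give a similar step on a ring without the existing methoxy group, and whether the lower number extends beyond this one cell line.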